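The compounds below may be only part of what the source reports. "The series", "measured", "known", "first", "only" and "open" are said of these compounds alone.

Of the compounds shown here, three from this series have been measured in a functional assay on HL-60 cells (Homo sapiens) for inhibition, read by sulforhodamine B assay, with a stated time of 48 h, tested at 10 uM; a lower number here means less inhibition, a higher number more inhibition at the concentration tested (going by the name of the read-out). Compound 1 `Brc1cn2ccnc2c(-c2ccc3ncn(C4CCCCC4)c3c2)n1` gives 18%. Compound 2 `c1ccc2c(-c3cn4ccnc4c(-c4ccc5ncn(C6CCCCC6)c5c4)n3)cccc2c1` gives 38.9%, and compound 3 `Fc1ccc(-c2cn3ccnc3c(-c3ccc4ncn(C5CCCCC5)c4c3)n2)cc1` gives 2.03%, the lowest of the three numbers: the step of a number 16 percentage points lower from compound 1 to compound 3 (beyond the scatter) and the step of a number 36.9 percentage points lower from compound 2 to compound 3 (beyond the scatter) both run downward to it. Compound 4 `Clc1ccc(-c2cn3ccnc3c(-c3ccc4ncn(C5CCCCC5)c4c3)n2)cc1` differs from compound 3 by chloro in place of fluoro on an aromatic carbon. Among the measured compounds shown here, no measured step exchanges one halogen for another on that ring; the two steps that reach compound 3 replace a whole group and therefore say little about this smaller change. Accordingly, compound 4 is expected to stay close to compound 3, with an estimated step of a number 6 percentage points higher from compound 3 to compound 4 (within the scatter) in this assay . The estimate for compound 4 is 8%, expected between 0% and 25%.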

Compound 4, a percentage reported as inhibition, at one concentration (the size of the read-out at that concentration, not a potency): 15.6%
Compound 4: middle estimate off by 7.6 percentage points, on the low side; low and high end bracket the measured number.
By their numbers in this assay, from the lowest: compound 3; then compounds 4 and 1 (each within the scatter of the next); then compound 2.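

In this assay the exchange of one halogen for another on this ring is enough to move the number, with a number 13.6 percentage points higher from compound 3 to compound 4 (beyond the scatter). With chloro on the ring, the 4-chlorophenyl group can no longer be told apart from the bromo of compound 1, with a number 2.4 percentage points lower from compound 1 to compound 4 (within the scatter), yet it still falls well short of naphthalen-1-yl, with a number 23.3 percentage points lower from compound 2 to compound 4 (beyond the scatter). Nothing available accounts for the gap between chloro and fluoro at this place. As far as these compounds go, it remains open whether the rise from fluoro to chloro continues with bromo on that ring. From the compounds shown here alone, how a 4-methoxyphenyl or 4-aminophenyl group would read here is also open.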